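A few compounds are considered here, and "the series" means these few. Any claim that something is new, unique, unknown or untested is made for them only; others in the source may bear on it.

Going by the values given here, compound 1 `CC#Cc1cncc(-c2ccc3c(c2)[C@@]2(COC(N)=N2)c2cc(Cl)ncc2O3)c1` is the only one of three compounds with an actual number in an ADME assay on microsomes from liver (Rattus norvegicus) for metabolic stability, read by LC-MS, using NADPH, with a stated time of 30 min, tested at 1 uM; on this read-out higher numbers stand for fast clearance and lower numbers for slow clearance: compound 1 gives 21 mL.min-1.g-1. Compound 2 `NC1=N[C@@]2(CO1)c1cc(NC(=O)c3ccc(Cl)cn3)ccc1Oc1cnc(Cl)cc12` reports only a limit of the assay, < 14 mL.min-1.g-1, not a number. Compound 3 `Cc1cc2c(cn1)Oc1ccc(NC(=O)c3ccc(Cl)cn3)cc1[C@@]21COC(N)=N1` likewise reports only a limit, < 14 mL.min-1.g-1. Two of the three values thus sit at the limit of < 14 mL.min-1.g-1 in this assay, at which 2 of the 3 values shown sit. The step of an at least 1.5-fold lower number from compound 1 to compound 2 (0.17 log units; that floor lies within the scatter) changes a different part of the shared core; the step that the two limits leave unreadable from compound 2 to compound 3 changes the same place as the change to compound 4 but cannot be read. Compound 4 `CC#Cc1cncc(-c2ccc3c(c2)[C@@]2(COC(N)=N2)c2cc(C4=CCCOC4)ncc2O3)c1` carries a group of 6 heavy atoms (5 carbon, 1 oxygen; one six-membered non-aromatic ring with 1 hetero atom) in place of one chlorine atom, on an aromatic carbon. Among the compounds with values here, no measured step bears clearly on this change, so in this assay a step of no readable direction is expected. Compound 4 is expected to give 30 mL.min-1.g-1, between 14 mL.min-1.g-1 and 65 mL.min-1.g-1, a step of a 1.4-fold higher number from compound 1 to compound 4 (0.15 log units; within the scatter).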

Compound 4, intrinsic clearance in microsomes: 45 mL.min-1.g-1
Estimate against measurement, compound 4: 1.5-fold (0.18 log units) below; the range from low to high includes it.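

Going by these compounds alone, this is the first readable step at this position, on an aromatic carbon next to the ring nitrogen: in this assay, the ring with a double bond in place of chloro gives a 2.1-fold higher number from compound 1 to compound 4 (0.33 log units; beyond the scatter). Clearance at this place therefore responds to what is attached, though modestly. Nothing shown gives a cause for this rise. Going by these compounds, whether a fully saturated six-membered ring, a methoxy group or an amine here would behave the same way stays open. The step from compound 2 to compound 3, at the same place, cannot be read: the limit of < 14 mL.min-1.g-1 in this assay, at which 2 of the 4 values shown sit.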